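Chloro for Fluoro: From Compound 1 to Compound 4

This account rests on a few compounds, and the source may have more. Where it says the series, first, only, none or still open, it means among the compounds named here.

Measured compounds:
compound 1, `N#C[Se]c1ccc(NC(=O)Oc2ccc(F)cc2)cc1`, 48400 nM
compound 2, `C=CCOC(=O)Nc1ccc([Se]C#N)cc1`, 50100 nM
compound 3, `Cc1ccc(OC(=O)Nc2ccc([Se][Se]c3ccc(NC(=O)Oc4ccc(C)cc4)cc3)cc2)cc1`, 57000 nM

Of the compounds shown here, three have been tested in a functional assay on HTB-54 cells (Homo sapiens) for cytotoxicity, read by MTT assay, with a stated time of 72 h; on this read-out lower numbers stand for stronger inhibition of growth and higher numbers for weaker inhibition of growth. Compound 1 gives 48400 nM, which is the lowest of the three numbers, but the others sit close by: compound 2 gives 50100 nM and compound 3 gives 57000 nM, and both differences from compound 1 lie within the usual scatter of this assay, so the three compounds are not separated from one another. For the measured compounds named here, no pair of measured compounds differs in only one place, so no measured step is available to lean on.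

Compound 4, `N#C[Se]c1ccc(NC(=O)Oc2ccc(Cl)cc2)cc1`, is not yet measured. It differs from compound 1 by chloro in place of fluoro on an aromatic carbon. Nothing in the three measured compounds points in either direction for such a change, so the step expected in this assay is none beyond the scatter. The estimated step from compound 1 to compound 4 is a 1.1-fold lower number from compound 1 to compound 4 (0.03 log units; within the scatter). Compound 4 is therefore expected to give 45000 nM, with a range from 20000 nM to 100000 nM.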

Compound 4, concentration for total growth inhibition: 41400 nM
Compound 4: the middle estimate sits 1.1-fold (0.04 log units) above what was measured, and the stated range covers the measured number.
By their numbers in this assay, from the lowest: compounds 4, 1, 2 and 3 (each within the scatter of the next).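

Chloro in place of fluoro on an aromatic carbon, para to a large group, gives in this assay a 1.2-fold lower number from compound 1 to compound 4 (0.07 log units; within the scatter). This is the only pair shown that differs in one place, and it gives the first direct reading at this position: exchanging these two substituents leaves the number within the scatter, so this assay does not separate compound 1 from compound 4. Nothing available explains why the two compounds read alike.

As far as these compounds go, whether any substituent at this position can move the number beyond the scatter remains open, since only fluoro and chloro can be compared there, and an amine, a carboxylic acid or a longer chain might behave differently. The pair also says nothing about changes elsewhere in the core of compound 1, such as replacing the nitrile on selenium.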